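From isopropyl to isobutyl on a sulfur

The compounds below may be only part of what the source reports. "The series", "measured", "known", "first", "only" and "open" are said of these compounds alone.

Measured in a functional assay on HCT-116 cells (Homo sapiens) for cytotoxicity, read by MTT assay, with a stated time of 72 h (a higher number here means a weaker inhibitor, a lower number a stronger inhibitor), so far:
- Compound 1 `CC[S+]([O-])CCCCN=C=S` gives 3850 nM
- Compound 2 `CC(C)[S+]([O-])CCCCN=C=S` gives 3740 nM

Compound 2 at 3740 nM cannot be told apart from compound 1 on these two numbers. The change to compound 3 `CC(C)C[S+]([O-])CCCCN=C=S` is isobutyl in place of isopropyl on a sulfur and puts isobutyl in place of isopropyl on a sulfur. Going by the values given here, one measured step bears on this, a 1.0-fold lower number from compound 1 to compound 2 (0.01 log units; within the scatter) and it lies within the scatter. That step also made a small change to the group on the same sulfur, adding a methyl in place of hydrogen. Among the compounds with values here, two compounds establish no pattern, but with only this step as a guide, no shift beyond the scatter is expected in this assay for the new change. The expected step of a 1.1-fold lower number from compound 2 to compound 3 (0.03 log units; within the scatter) would stay within the scatter. For compound 3 the estimate is 3500 nM with an expected range from 1900 nM to 6500 nM in repeated measurements.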

Compound 3, half-maximal inhibitory concentration: 2060 nM
Beside the measured number, compound 3's estimate is 1.7-fold (0.23 log units) above it; the measured number falls inside the stated range.
By their numbers in this assay, from the lowest: compounds 3, 2 and 1 (each within the scatter of the next).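

In this assay, isobutyl in place of isopropyl on a sulfur gives a 1.8-fold lower number from compound 2 to compound 3 (0.26 log units; within the scatter) and so does not separate the two compounds, even though this step is bigger in size than a 1.0-fold lower number from compound 1 to compound 2 (0.01 log units; within the scatter) from the earlier pair. The wider comparison gives a 1.9-fold lower number from compound 1 to compound 3 (0.27 log units; within the scatter) as well, so all three groups tried on this sulfur remain within the scatter of one another, and this position has so far accepted each of these changes without a clear shift in the number. Nothing available here explains the size of these steps.

On these data alone, whether a longer chain, a phenyl ring or an amine on this sulfur would move the number beyond the scatter remains open. These three compounds also cannot show whether the same small steps would appear in other cell lines.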